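The source may hold more compounds than are shown below. What is called first, only, known or untested is meant among the compounds shown, and "the series" means these compounds.

For the measured compounds named here, in a functional assay on RS4-11 cells (Homo sapiens) for inhibition, read by CCK-8 assay, with a stated time of 48 h (a higher number here means a weaker inhibitor, a lower number a stronger inhibitor), compound 1 (`O=C(Nc1cccc([N+](=O)[O-])c1)N1CCN(S(=O)(=O)c2sccc2-c2ccccc2Oc2ccc(O)c(O)c2)CC1`) gives 9800 nM as the only exact number so far. Compound 2 (`COc1ccc(Oc2ccccc2-c2ccsc2S(=O)(=O)N2CCN(C(=O)Nc3cccc([N+](=O)[O-])c3)CC2)cc1OC`) carries 3,4-dimethoxyphenyl in place of 3,4-dihydroxyphenyl on an oxygen on an aromatic ring and reads > 50000 nM as a limit of the assay, not a number. Going by the values given here, the one measured step is an at least 5.1-fold higher number from compound 1 to compound 2 (0.70 log units; beyond the scatter) and ends at the limit of > 50000 nM in this assay, at which 1 of the 2 values shown sits, rather than at a number.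

Compound 3 (`O=C(Nc1ccc(F)cc1)N1CCN(S(=O)(=O)c2sccc2-c2ccccc2Oc2ccc(O)c(O)c2)CC1`) differs from compound 1 elsewhere, with 4-fluorophenyl in place of 3-nitrophenyl on an amide-type nitrogen as the counted change: 4-fluorophenyl in place of 3-nitrophenyl on an amide-type nitrogen. Among the compounds with values here, no measured step touches that nitrogen, so the one step available gives no size for this change. Compound 3 keeps the 3,4-dihydroxyphenyl group, so the expectation starts from compound 1 at 9800 nM and, in this assay again, foresees no step beyond the scatter in either direction. The expected step is a 1.1-fold lower number from compound 1 to compound 3 (0.04 log units; within the scatter) in this estimate. For compound 3 the estimated value is 9000 nM with 2500 nM as the expected lower end and 32000 nM as the upper end.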

Compound 3, half-maximal inhibitory concentration: 6800 nM
Beside the measured number, compound 3's estimate is 1.3-fold (0.12 log units) above it, and the stated range covers the measured number.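

The earlier step changed only the group on the oxygen and left the amide-type nitrogen untouched; here, in this assay, 4-fluorophenyl in place of 3-nitrophenyl gives a 1.4-fold lower number from compound 1 to compound 3 (0.16 log units; within the scatter) with the 3,4-dihydroxyphenyl group kept. The change takes away the 3-nitrophenyl group with its 2 hydrogen-bond acceptors and brings in a group counted with none, yet the two numbers stay within the usual scatter of each other, so in this pair the 3-nitrophenyl group is not required for the inhibition read in this assay. Nothing measured here gives a reason why these two groups on the amide-type nitrogen read alike.

Going by these compounds, both groups at this nitrogen are substituted phenyl rings, so it remains open whether a pyridine ring, a cyclohexyl group or a phenyl ring carrying a carboxylic acid would shift the number beyond the scatter. On these data alone, it is also open whether a single hydroxyl group on the phenyl ring, in place of the 3,4-dihydroxyphenyl group, would keep the number close to that of compound 3 at 6800 nM in this assay.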